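Halogen swap on the benzylsulfanyl ring: chloro to fluoro

A few compounds are considered here, and "the series" means these few. Any claim that something is new, unique, unknown or untested is made for them only; others in the source may bear on it.

Compound 2 `CC1=C(C(=O)Nc2ccc(Br)cc2)C(c2ccc(Cl)cc2Cl)N=C(SCc2ccc(Cl)cc2)N1` was tested in a functional assay on the whole organism (artery, strain albino) with Rattus norvegicus as the target, with a stated time of 60 min, at a dose of 10 mg/kg by the oral route (a higher number here means more inhibition at the dose given (going by the name of the read-out), a lower number less inhibition), and gave 11.8%, level with compound 1 `CC1=C(C(=O)Nc2ccc(Br)cc2)C(c2ccc(Cl)cc2Cl)N=C(SCc2ccccc2Cl)N1`, which gives 11.8%. Within the data shown here, the single measured step, no change at the digits printed from compound 1 to compound 2 (within the scatter), moved the benzylsulfanyl substituent from one ring position to another without a change beyond the scatter. Compound 3 `CC1=C(C(=O)Nc2ccc(Br)cc2)C(c2ccc(Cl)cc2Cl)N=C(SCc2ccc(F)cc2)N1` differs from compound 2 by fluoro in place of chloro on an aromatic carbon. Among the measured compounds shown here, no measured step exchanges one halogen for another, so the only bearing evidence is the flat step from compound 1 to compound 2. The step of a number 0.2 percentage points higher from compound 2 to compound 3 (within the scatter) is therefore expected to stay within the scatter, and compound 3 is estimated at 12%, between 0% and 25%.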

Compound 3, a percentage reported as inhibition, in the whole organism at one dose (the size of the read-out at that dose, not a potency): 16.9%
Compound 3: middle estimate off by 4.9 percentage points, on the low side, within the range that was stated.
By their numbers in this assay, from the lowest: compounds 1, 2 and 3 (each within the scatter of the next).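

In this assay, the exchange of one halogen for another on this ring gives a number 5.1 percentage points higher from compound 2 to compound 3 (within the scatter), so fluoro in place of chloro is not separated from the scatter at this position. Changing the halogen and its ring position together gives a number 5.1 percentage points higher from compound 1 to compound 3 (within the scatter), which is also not separated from the scatter. Nothing at hand bears on why these numbers fall as they do. Open, from the compounds shown here alone, is whether an amine, a carboxylic acid or a methoxy group on this ring would give a step beyond the scatter.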